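Swapping the N-aryl group on a triaryl-imidazole chromone

The source may report more compounds than this note shows. Statements on the series, on what has been measured and on what is new or still open speak of the compounds shown alone.

Measured compounds:
compound 1 `Cc1cc2occ(-c3nc(-c4ccccc4)c(-c4ccccc4)n3-c3ccc(Cl)c(Cl)c3)c(=O)c2cc1Cl` — 1560 nM
compound 2 `COc1cccc(-n2c(-c3coc4cc(C)c(Cl)cc4c3=O)nc(-c3ccccc3)c2-c2ccccc2)c1` — 25000 nM
compound 3 `Cc1ccc(-n2c(-c3coc4cc(C)c(Cl)cc4c3=O)nc(-c3ccccc3)c2-c2ccccc2)cc1` — 12500 nM

In a functional assay on MCF7 cells (Homo sapiens) for inhibition, read by MTT assay, with a stated time of 72 h (a lower number here means a stronger inhibitor, a higher number a weaker inhibitor), compound 2 gives the highest number of the three, 25000 nM. Compound 3 lies close by, with a 2.0-fold lower number from compound 2 to compound 3 (0.30 log units; within the scatter). Compound 1, the only one bearing a halogenated aryl group on the ring nitrogen, stands far off: a 16-fold higher number from compound 1 to compound 2 (1.20 log units; beyond the scatter) and an 8.0-fold higher number from compound 1 to compound 3 (0.90 log units; beyond the scatter).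

Compound 4 `Cc1cc2occ(-c3nc(-c4ccccc4)c(-c4ccccc4)n3-c3ccc(Br)cc3)c(=O)c2cc1Cl` is not yet measured. The change from compound 2 to compound 4 is 4-bromophenyl in place of 3-methoxyphenyl on an aromatic nitrogen.

Within the data shown here, two steps bear on this. The step from compound 1 to compound 2 shows that replacing a halogenated aryl group with 3-methoxyphenyl raised the number greatly; the step from compound 1 to compound 3 shows a modest rise for 4-methylphenyl. Returning halogen to the aryl group is therefore expected to lower the number well beyond the scatter, though a single bromine may not reach compound 1. Compound 4 is expected to fall at 5000 nM, within 1500 nM to 16000 nM, meaning an estimated 5.0-fold lower number from compound 2 to compound 4 (0.70 log units; beyond the scatter).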

Compound 4, half-maximal inhibitory concentration: 1560 nM
The estimate for compound 4 lay 3.2-fold (0.51 log units) above the measured number; measured number inside the range.
By their numbers in this assay, from the lowest: compounds 1 and 4 (each within the scatter of the next); then compounds 3 and 2 (each within the scatter of the next).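

Compound 4 shows that the full 3,4-dichlorophenyl group is not needed at this aromatic nitrogen: in this assay, 4-bromophenyl gives a 16-fold lower number from compound 2 to compound 4 (1.20 log units; beyond the scatter) and shows no change at the digits printed from compound 1 to compound 4 (within the scatter) when set against the dichlorinated group. Among these compounds, the closest comparison is an 8.0-fold lower number from compound 3 to compound 4 (0.90 log units; beyond the scatter) with bromo in place of methyl as the only change, so the group on that one aromatic carbon is enough to separate the two compounds. Across the four compounds, the two with halogen on the aryl group stand apart from the two without it, and none goes against this split.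

On these data alone, it remains open whether fluoro, iodo, an amine or a carboxylic acid on this phenyl ring would follow the same split. Nothing available here accounts for the split.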